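The source may hold more compounds than are shown below. What is called first, only, known or untested is meant among the compounds shown, and "the series" means these compounds.

In an ADME assay on Vero cells (Chlorocebus sabaeus) for cytotoxicity, read by resazurin assay, with a stated time of 72 h (a lower number here means a stronger inhibitor, a higher number a weaker inhibitor), compound 2 (`O=C(CCN1CCN(c2ccc([N+](=O)[O-])cc2)CC1)c1ccc(F)cc1`) gives 111000 nM. Compound 3 (`O=C(CCN1CCN(c2ccc([N+](=O)[O-])cc2)CC1)c1ccc(Cl)c(F)c1`) gives 89200 nM, within the scatter of compound 2, while compound 1 (`COc1ccc(N2CCN(CCC(=O)c3ccc(F)cc3)CC2)cc1`) gives 31900 nM. Compound 2 thus stands together with compound 3 at the high end of the three numbers, with compound 1 clearly apart from both.

The next compound, compound 4 (`O=C(CCN1CCN(c2ccc([N+](=O)[O-])cc2)CC1)c1ccc(OC(F)(F)F)cc1`), has trifluoromethoxy in place of fluoro on an aromatic carbon, para to a large group: trifluoromethoxy in place of fluoro on an aromatic carbon. Going by the values given here, no measured compound yet carries trifluoromethoxy, so the estimate rests on neighbouring steps. The closest is the other change made to the group on the carbonyl carbon, where 4-chloro-3-fluorophenyl replaces 4-fluorophenyl. That step, a 1.2-fold lower number from compound 2 to compound 3 (0.09 log units; within the scatter), stays within the scatter. The larger step, a 3.5-fold higher number from compound 1 to compound 2 (0.54 log units; beyond the scatter), is modest and puts nitro in place of methoxy, a change that does not separate compound 4 from compound 2, since both carry the nitro group. In this assay, no step beyond the scatter is therefore expected, though this rests on a single precedent. The estimated change is a 1.2-fold lower number from compound 2 to compound 4 (0.09 log units; within the scatter). For compound 4 the expected value is 90000 nM, with an estimated range of 42000 nM to 175000 nM.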

Compound 4, half-maximal inhibitory concentration: 93200 nM
The estimate for compound 4 lay 1.0-fold (0.02 log units) below the measured number; measured number inside the range.
By their numbers in this assay, from the lowest: compound 1; then compounds 3, 4 and 2 (each within the scatter of the next).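

In this assay, trifluoromethoxy in place of fluoro on an aromatic carbon, para to a large group, gives a 1.2-fold lower number from compound 2 to compound 4 (0.08 log units; within the scatter) and so shows that a group of 5 heavy atoms, including a hydrogen-bond acceptor, can replace a single fluorine here without a step beyond the scatter. Together with a 1.2-fold lower number from compound 2 to compound 3 (0.09 log units; within the scatter) as the earlier change to the group on the carbonyl carbon, this makes two changes there that stay within the scatter, whereas the one step beyond it among the compounds shown, a 3.5-fold higher number from compound 1 to compound 2 (0.54 log units; beyond the scatter), exchanges methoxy for nitro elsewhere in the molecule. Nothing measured here accounts for the small size of the new step.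

As far as these compounds go, the groups compared on this aromatic ring all carry halogen, so it remains open whether an amine, a carboxylic acid or an unsubstituted phenyl would also stay within the scatter of compound 2. From the compounds shown here alone, it also remains open whether trifluoromethoxy would give a similar result alongside methoxy rather than nitro, or whether a longer chain carrying the carbonyl would alter the picture.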